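The source may hold more compounds than are shown below. What is called first, only, known or untested is meant among the compounds shown, and "the series" means these compounds.

Among the measured compounds shown here, compound 3 `O=C1OCCN1C(=O)c1ccc(Oc2cccc(Cl)c2)cc1` is the only member of this set with a number: in an assay on HEK293 cells for inhibition of N-acylethanolamine-hydrolyzing acid amidase (Rattus norvegicus), read by LC-MS, with a stated time of 30 min (a lower number here means a stronger inhibitor, a higher number a weaker inhibitor), compound 3 gives 7740 nM. Compound 1 `O=C(CCCCCc1ccc(I)cc1)N1CCOC1=O` reaches only a limit of the assay, > 20000 nM, in this assay. Compound 2 `NC(=O)c1ccc(CCCCCC(=O)N2CCOC2=O)cc1` likewise reaches only a limit, > 20000 nM. The step that the two limits leave unreadable from compound 1 to compound 2 is therefore unreadable, which follows from the limit of > 20000 nM in this assay, at which 2 of the 3 values shown sit. Compound 4 `CCCCCCOc1ccc(C(=O)N2CCOC2=O)cc1` differs from compound 3 by hexyl in place of 3-chlorophenyl on an oxygen on an aromatic ring. For the measured compounds named here, no measured step touches a change at this oxygen, and the only readable number belongs to compound 3, so no direction beyond the scatter can be drawn for this change. Compound 4 is therefore expected to show a step of only a 1.3-fold higher number from compound 3 to compound 4 (0.11 log units; within the scatter). The estimate for compound 4 is 10000 nM, with a range from 2500 nM to 40000 nM.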

Compound 4, half-maximal inhibitory concentration: 640 nM
For compound 4 the middle estimate is 16-fold (1.19 log units) above the measured one; measured number below the stated range.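

In this assay hexyl in place of 3-chlorophenyl on an oxygen on an aromatic ring gives a 12-fold lower number from compound 3 to compound 4 (1.08 log units; beyond the scatter) and so shows that this oxygen is a place where the group attached changes the number beyond the scatter. Among the compounds shown here, it is the first readable step in the set, because the only earlier step cannot be read: the limit of > 20000 nM in this assay, at which 2 of the 4 values shown sit.

The compounds shown leave open whether losing the ring or losing the chlorine carries this step. They also leave open how a longer chain such as octyl, or a chain ending in an amine, would read on this oxygen.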